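The compounds below may be only part of what the source reports. "The series", "measured", "known", "first", "only" and "open" are said of these compounds alone.

Measured so far:
Compound 1 `C=CC1=C(C(=O)NCc2ccccc2)C(c2ccc(OC)cc2)OC1` — in a functional assay on HeLa cells (Homo sapiens) for cytotoxicity, read by MTT assay, with a stated time of 24 h (a higher number here means a weaker inhibitor, a lower number a stronger inhibitor), compound 1 gives > 100000 nM, a limit of the assay.
Compound 2 `C=CC1=C(C(=O)Nc2ccc(OCC)cc2)C(c2ccc(OC)cc2)OC1` — in this assay compound 2 gives > 100000 nM, again a limit of the assay.

Compound 2 thus stands at the limit, as does compound 1 (the limit of > 100000 nM in this assay, at which 2 of the 2 values shown sit). For the measured compounds named here, the one measured step, a step that the two limits leave unreadable from compound 1 to compound 2, stays unreadable between two limits. Compound 3 `C=CC1=C(C(=O)Nc2ccccc2)C(c2ccc(OC)cc2)OC1` differs from compound 2 by hydrogen in place of ethoxy on an aromatic carbon. Going by the values given here, no measured step covers removal of the ethoxy; the single step available gives no readable size, so no movement out of the limit is expected. The step from compound 2 to compound 3 is expected as a step that the limit leaves unreadable from compound 2 to compound 3. Compound 3 in this assay is estimated at 200000 nM, within 60000 nM to 1000000 nM, most likely again reported only as a limit.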

Compound 3, half-maximal inhibitory concentration: > 100000 nM
Compound 3: no number, only a limit; the forecaster's own chance of this, stated with the estimate: 85%; the middle value is on the limit's open side.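

No step size can be read from compound 3 to compound 1 or compound 2, as all three compounds are reported only as limits: the limit of > 100000 nM in this assay, at which 3 of the 3 values shown sit.

The compounds shown leave open whether any group on the amide-type nitrogen gives a measurable value in this assay.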